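The source may hold more compounds than are shown below. What is called first, only, known or untested is meant among the compounds shown, and "the series" means these compounds.

Working notes on the series. Among the compounds with values here, compound 1 `COc1ccccc1-n1nc(C2CC(C)(C)OC(C)(C)C2)cc1-c1ccnc(Cl)c1` is the only member of the set with a number in hand: in an assay on HEK293 cells for inhibition of Voltage-dependent N-type calcium channel subunit alpha-1B (Homo sapiens), read by patch clamp, using a membrane potential dye (on this read-out higher numbers stand for weaker inhibition and lower numbers for stronger inhibition), compound 1 gives 740 nM. Within the data shown here, a second member, compound 2 `COc1ccccc1-n1nc([C@@H]2CCO[C@@H](C(C)C)C2)cc1-c1ccc(Cl)cc1`, has no number: in this assay compound 2 gives "not determined" (no result reported), so compound 1 stands alone on the numbers and offers no step to compare against. Compound 3 `CCOc1ccc(-c2cc(C3CC(C)(C)OC(C)(C)C3)nn2-c2ccccc2OC)cn1` is not yet measured; it differs from compound 1 in one place, (6-ethoxypyridin-3-yl in place of 2-chloropyridin-4-yl on an aromatic carbon). Among the measured compounds shown here, nothing in the set shows what an exchange of this kind at this position of the shared core does to the read-out, and no step between measured compounds is available to calibrate the expectation. With the ring attachment shifted and a chlorine replaced by an ethoxy group, a loss of inhibition beyond the usual scatter is the working assumption, though a change within the scatter cannot be excluded. The step from compound 1 to compound 3 is expected to be a 2.7-fold higher number from compound 1 to compound 3 (0.43 log units; beyond the scatter). For compound 3 the estimate in this assay is 2000 nM, with a range from 500 nM to 8000 nM.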

Compound 3, half-maximal inhibitory concentration: 200 nM
Compound 3: the middle estimate sits 10-fold (1.00 log units) above what was measured; measured number outside the range, below it.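

In this assay, within the data shown here, putting 6-ethoxypyridin-3-yl in place of 2-chloropyridin-4-yl on the aromatic carbon next to the ring atom that bears a 2-methoxyphenyl group gives a 3.7-fold lower number from compound 1 to compound 3 (0.57 log units; beyond the scatter) and so stronger inhibition, which is the first reading of any change at this position of the shared core. The position therefore does not depend on the 2-chloropyridin-4-yl group or its chlorine for inhibition at this level, and it accepts an aromatic ring with a different attachment point that carries an ethoxy group. No measured evidence accounts for the gain in inhibition, and this single step gives no cause for it.

The step changes the attachment point of the ring and its substituent together, so the compounds shown do not separate the contribution of the ethoxy group from that of the shifted ring attachment; 2-ethoxypyridin-4-yl and 6-chloropyridin-3-yl would pull these two apart. Also open, as far as these compounds go, is how far the substituent can vary at this place, for instance whether a longer chain such as butoxy or an amine such as dimethylamino on the same ring carbon would keep the inhibition seen with compound 3.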